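The source may hold more compounds than are shown below. What is called first, only, known or untested is meant among the compounds shown, and "the series" means these compounds.

In a functional assay on MDA-MB-231 cells (Homo sapiens) for inhibition, read by sulforhodamine B assay, with a stated time of 48 h, tested at 10 uM (a lower number here means less inhibition, a higher number more inhibition at the concentration tested (going by the name of the read-out)), compound 1 `c1ccc(-c2cn3ccnc3c(-c3ccc4ncn(C5CCCCC5)c4c3)n2)cc1` gives 41.5%, while compound 2 `Fc1ccc(-c2cn3ccnc3c(-c3ccc4ncn(C5CCCCC5)c4c3)n2)cc1` gives 15.8%, the lowest of the two numbers; the step of a number 25.7 percentage points lower from compound 1 to compound 2 (beyond the scatter) lies beyond the scatter. Compound 3 `c1cn2cc(-c3ccsc3)nc(-c3ccc4ncn(C5CCCCC5)c4c3)c2n1` arises from compound 2 by thiophen-3-yl in place of 4-fluorophenyl on an aromatic carbon. Among the compounds with values here, no measured step swaps one ring for another at this place, so the single known step bears on it only indirectly, showing that what sits there can move inhibition by a modest amount in either direction. A step of a number 12.2 percentage points higher from compound 2 to compound 3 (beyond the scatter) is therefore expected, with wide uncertainty. Compound 3 is estimated at 28%, within 10% to 50%.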

Compound 3, a percentage reported as inhibition, at one concentration (the size of the read-out at that concentration, not a potency): 1.35%
Beside the measured number, compound 3's estimate is 26.7 percentage points above it, and the stated range ends above it.
By their numbers in this assay, from the lowest: compound 3; then compound 2; then compound 1.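

Swapping the whole ring at this place, and not only adding a fluoro group to it, also changes the result: a number 14.5 percentage points lower from compound 2 to compound 3 (beyond the scatter) in this assay, and a number 40.2 percentage points lower from compound 1 to compound 3 (beyond the scatter), a large drop. Among these three compounds, the plain phenyl of compound 1 therefore gives the highest number, and both changes at this place lower it. On these data alone, whether a ring bearing an amine or a carboxylic acid would hold or raise the number remains open, as does the effect of a longer chain here. Nothing available explains why thiophen-3-yl gives so little inhibition.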